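The source may hold more compounds than are shown below. What is called first, only, known or untested is meant among the compounds shown, and "the series" means these compounds.

Measured so far:
compound 1 `O=C(COc1cccc2ccccc12)N/N=C/C=C/c1ccccc1`: 100 ug/mL
compound 2 `O=C(COc1cccc2ccccc12)N/N=C/c1cccc(Br)c1`: 100 ug/mL

In an ADME assay on HEL cells (Homo sapiens) for cytotoxicity (on this read-out lower numbers stand for higher toxicity in this test and higher numbers for lower toxicity in this test), compound 1 gives 100 ug/mL. In this assay compound 2 gives 100 ug/mL, so compound 2 stands level with compound 1; the step of no change at the digits printed from compound 1 to compound 2 (within the scatter) shows nothing beyond the scatter, even though it exchanged one whole group for another on the carbon with a double bond to nitrogen.

Compound 3 `O=C(COc1cccc2ccccc12)N/N=C/c1ccccc1Cl` has not yet been measured in this assay. It differs from compound 2 in one place: 2-chlorophenyl in place of 3-bromophenyl on a carbon with a double bond to nitrogen. Among the measured compounds shown here, the only measured step that bears on this is the one from compound 1 to compound 2, which changed the group at the same position and left the read-out unchanged. The expected step is therefore no change at the digits printed from compound 2 to compound 3 (within the scatter), that is none beyond the scatter. Compound 3 is estimated at 100 ug/mL, with a range from 50 ug/mL to 200 ug/mL.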

Compound 3, minimum cytotoxic concentration: 100 ug/mL
Compound 3: middle estimate and measured number agree at the digits printed; the measured number falls inside the stated range.
By their numbers in this assay, from the lowest: compounds 1, 2 and 3 (each within the scatter of the next).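

In this assay, putting 2-chlorophenyl in place of 3-bromophenyl on the carbon with a double bond to nitrogen gives no change at the digits printed from compound 2 to compound 3 (within the scatter), so an exchange of one halogen-bearing phenyl group for another also leaves the read-out where it was. Against the 2-phenylethenyl group, the same 2-chlorophenyl group gives no change at the digits printed from compound 1 to compound 3 (within the scatter), which means that all three groups seen at this position now read alike, with no compound going against that. Nothing measured here offers an explanation for this sameness.

As far as these compounds go, it remains open whether a group of a different kind at this position, such as an amine, a carboxylic acid or a longer alkyl chain, would read the same. The compounds shown also leave open whether a change elsewhere in the shared core would move the read-out.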